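The source may report more compounds than this note shows. Statements on the series, on what has been measured and on what is new or still open speak of the compounds shown alone.

Measured so far, in a functional assay on MCF7 cells (Homo sapiens) for antiproliferative activity, read by MTT assay, with a stated time of 48 h; a higher number here means a weaker inhibitor, a lower number a stronger inhibitor:

Compound 1, `COc1ccc(-c2nn(-c3ccccc3)cc2CNc2ccc(F)cc2)cc1`: 5980 nM
Compound 2, `Clc1ccc(NCc2cn(-c3ccccc3)nc2-c2ccc(Cl)cc2)cc1`: 2280 nM
Compound 3, `Fc1ccc(NCc2cn(-c3ccccc3)nc2-c2ccc(Br)cc2)cc1`: 3960 nM

Compound 1 gives the highest number of the three. Its nearest neighbour is compound 3, and the step from compound 1 to compound 3 is a 1.5-fold lower number from compound 1 to compound 3 (0.18 log units; within the scatter), so the two cannot be told apart. Compound 2 stands further away, and the gap between compound 1 and compound 2 is beyond the scatter.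

The unmeasured compound 4, `COc1ccc(-c2nn(-c3ccccc3)cc2CNc2ccc(Br)cc2)cc1`, differs from compound 1 in one place: bromo in place of fluoro on an aromatic carbon.

Going by the values given here, no measured pair shows this exact exchange on this ring. Among the compounds with values here, the only step that touches a halogen for another group, from compound 1 to compound 3, is a 1.5-fold lower number from compound 1 to compound 3 (0.18 log units; within the scatter), and it concerns the other aromatic ring. Compounds 2 and 3 carry different halogens on both rings at once, so their values cannot be split into single exchanges. On this basis the step from compound 1 to compound 4 in this assay is expected to be small and uncertain in direction, most likely within the scatter.

Compound 4 is therefore expected to give about 4500 nM, with a likely range from 2000 nM to 10000 nM, which means an expected step of a 1.3-fold lower number from compound 1 to compound 4 (0.12 log units; within the scatter).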

Compound 4, half-maximal inhibitory concentration: 7020 nM
Beside the measured number, compound 4's estimate is 1.6-fold (0.19 log units) below it, within the range that was stated.
By their numbers in this assay, from the lowest: compounds 2, 3, 1 and 4 (each within the scatter of the next, the first and the last beyond it).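

In this assay, the exchange of fluoro for bromo on the (4-fluorophenyl)amino group gives a 1.2-fold higher number from compound 1 to compound 4 (0.07 log units; within the scatter), and this is the only single exchange shown at this position. With the methoxy group on the other aromatic ring held fixed, fluoro and bromo at this place, para to a large group, cannot be told apart, so the exchange brings no measurable gain or loss. No measurement is available that would explain this result.

The compounds shown leave open whether a different kind of group at this position, such as a carboxylic acid or an amine, would move the number beyond the scatter. They also leave open whether the same exchange would read the same with bromo in place of methoxy on the other aromatic ring.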